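The source may report more compounds than this note shows. Statements on the series, on what has been measured and on what is new or still open speak of the compounds shown alone.

Compound 1 `Clc1ccc(/C=C2\CCCN=C2c2cccnc2)cc1` gives 970 nM in an assay on membranes from brain for displacement of a labelled ligand from Neuronal acetylcholine receptor; alpha4/beta2 (Rattus norvegicus), with a stated time of 3 h; a lower number here means a stronger inhibitor, a higher number a weaker inhibitor. Among the measured compounds shown here, compound 2 `CCCCOc1ccc(/C=C2\CCCN=C2c2cccnc2)cc1` gives 1960 nM and stands at the higher of the two numbers measured so far; the only step in hand, a 2.0-fold higher number from compound 1 to compound 2 (0.31 log units; beyond the scatter), is modest but beyond the scatter. Compound 3 `FC(F)Oc1ccc(/C=C2\CCCN=C2c2cccnc2)cc1` differs from compound 2 by difluoromethyl in place of butyl on an oxygen on an aromatic ring. For the measured compounds named here, the step from compound 1 to compound 2 is the one comparison that bears on this change, and with the difluoromethyl group smaller than the butyl it replaces, a modest move back toward compound 1 is expected, a 1.5-fold lower number from compound 2 to compound 3 (0.18 log units; within the scatter). Compound 3 is therefore estimated at 1300 nM, within 550 nM to 3000 nM.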

Compound 3, inhibition constant: 1160 nM
Estimate against measurement, compound 3: 1.1-fold (0.05 log units) above; measured number inside the range.
By their numbers in this assay, from the lowest: compounds 1, 3 and 2 (each within the scatter of the next, the first and the last beyond it).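

In this assay, difluoromethyl in place of butyl on the oxygen gives a 1.7-fold lower number from compound 2 to compound 3 (0.23 log units; within the scatter), and changing the chloro group to difluoromethoxy gives a 1.2-fold higher number from compound 1 to compound 3 (0.08 log units; within the scatter). Both steps lie within the scatter, so compound 3 is resolved from neither compound 1 nor compound 2, although those two are resolved from each other. No measurement here bears on the reason for these numbers. From the compounds shown here alone, whether an amine or a carboxylic acid at this place, or a longer chain on the oxygen, would give a step beyond the scatter remains open.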